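Adding a Second Chloro to the Terminal Phenyl

The source may hold more compounds than are shown below. What is called first, only, known or untested is meant among the compounds shown, and "the series" means these compounds.

Compound 1 `CCN(CC)CCCNc1nc(-c2ccc(NC(=O)Nc3ccccc3)cc2)nc2c(Cl)c(Cl)sc12` gives 1780 nM in a functional assay on MDA-MB-231 cells (Homo sapiens) for cytotoxicity, read by MTT assay, with a stated time of 72 h; on this read-out lower numbers stand for stronger inhibition and higher numbers for weaker inhibition.
Compound 2 `CCN(CC)CCCNc1nc(-c2ccc(NC(=O)Nc3ccc(Cl)cc3)cc2)nc2c(Cl)c(Cl)sc12` gives 660 nM in this assay.
Compound 3 `CCN(CC)CCNc1nc(-c2ccc(NC(=O)Nc3ccccc3Cl)cc2)nc2ccsc12` gives 680 nM in this assay.

Compound 1 and compound 2 share one core, while compound 3 is built on another; the difference between the two cores is not broken down here. Within the first pair, the change chloro in place of hydrogen on an aromatic carbon gave a 2.7-fold lower number from compound 1 to compound 2 (0.43 log units; beyond the scatter). Compound 3 sits close to compound 2 in number and clearly apart from compound 1.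

Compound 4 `CCN(CC)CCNc1nc(-c2ccc(NC(=O)Nc3ccc(Cl)cc3Cl)cc2)nc2ccsc12` is not yet measured. It differs from compound 3 by chloro in place of hydrogen on an aromatic carbon, the same kind of change as that between compound 1 and compound 2, though here the entering chloro sits meta to a chloro group as well as para to a large group, and the core is different. On the strength of the step from compound 1 to compound 2, the writer expects compound 4 to show a 1.9-fold lower number from compound 3 to compound 4 (0.29 log units; within the scatter) in this assay, again modest. The expected value for compound 4 is 350 nM, between 150 nM and 900 nM.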

Compound 4, half-maximal inhibitory concentration: 2480 nM
For compound 4 the middle estimate is 7.1-fold (0.85 log units) below the measured one, outside the stated range (above it).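

On the core of compound 3, chloro in place of hydrogen on an aromatic carbon gave a 3.6-fold higher number from compound 3 to compound 4 (0.56 log units; beyond the scatter) in this assay, the opposite direction to the earlier step. Set side by side, the two steps show that this change did not carry over from one core to the other in this series: the same change on two cores in this assay, a 2.7-fold lower number (0.43 log units; beyond the scatter) from compound 1 to compound 2 and a 3.6-fold higher number (0.56 log units; beyond the scatter) from compound 3 to compound 4, 9.8-fold (0.99 log units) apart, beyond the scatter of two such steps. This does not show that the core alone sets the direction, since in the second pair the entering chloro also sits meta to a chloro group, and the compounds shown cannot separate that from the change of core.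

The compounds shown leave open how a single chloro in the same place, without the chloro of the 2-chlorophenyl group, would behave on the core of compound 3, and how the 2,4-dichlorophenyl group would behave on the core of compound 1. On these data alone, whether a fluoro or a methoxy group entering at the same place would follow either step also remains open.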